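Aryl swap at the benzyl ether: outlook for compound 4

A few compounds are considered here, and "the series" means these few. Any claim that something is new, unique, unknown or untested is made for them only; others in the source may bear on it.

Measured compounds:
compound 1 `Cc1ccc(NC(=O)NC(=O)c2ccc(OCc3cccc(Cl)c3)cc2)cc1-c1nc2ccccc2[nH]1`: 16000 nM
compound 2 `Cc1ccc(NC(=O)NC(=O)c2ccc(OCc3cccc(C(F)(F)F)c3)cc2)cc1-c1nc2ccccc2[nH]1`: 9640 nM
compound 3 `Cc1ccc(COc2ccc(C(=O)NC(=O)Nc3ccc(C)c(-c4nc5ccccc5[nH]4)c3)cc2)cc1`: 26000 nM

In a functional assay on SW-620 cells (Homo sapiens) for inhibition, read by MTT assay, with a stated time of 48 h (a higher number here means a weaker inhibitor, a lower number a stronger inhibitor), the three measured compounds sit close together. Compound 3 gives the highest number of the three: its gap to compound 1, a 1.6-fold higher number from compound 1 to compound 3 (0.21 log units; within the scatter), is within the scatter, while a 2.7-fold higher number from compound 2 to compound 3 (0.43 log units; beyond the scatter) is beyond it.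

Compound 4 `Cc1ccc(NC(=O)NC(=O)c2ccc(OCc3ccccc3Cl)cc2)cc1-c1nc2ccccc2[nH]1` differs from compound 3 by 2-chlorophenyl in place of 4-methylphenyl on a saturated chain carbon bound to an oxygen on an aromatic ring. Going by the values given here, two measured steps bear on a change of this kind at the same place. a 1.6-fold higher number from compound 1 to compound 3 (0.21 log units; within the scatter) shows that exchanging 3-chlorophenyl for 4-methylphenyl did not move the number beyond the scatter; a 2.7-fold higher number from compound 2 to compound 3 (0.43 log units; beyond the scatter) shows a modest rise. Among the compounds with values here, compound 4 reverses the first of these in kind, with chloro returning, but as 2-chlorophenyl rather than 3-chlorophenyl, and no measured compound carries 2-chlorophenyl. The expectation is therefore a small step to a lower number, a 1.7-fold lower number from compound 3 to compound 4 (0.24 log units; within the scatter), at the edge of the scatter. Compound 4 is estimated at 15000 nM, with a range from 6000 nM to 38000 nM.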

Compound 4, half-maximal inhibitory concentration: 35700 nM
The estimate for compound 4 lay 2.4-fold (0.38 log units) below the measured number; low and high end bracket the measured number.
By their numbers in this assay, from the lowest: compounds 2, 1, 3 and 4 (each within the scatter of the next, the first and the last beyond it).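

In this assay, going by these compounds alone, the step of a 2.2-fold higher number from compound 1 to compound 4 (0.35 log units; beyond the scatter) is the first sign that the place of the chloro on the phenyl ring counts, since 2-chlorophenyl and 3-chlorophenyl lie beyond the scatter of each other, though only modestly. The step of a 3.7-fold higher number from compound 2 to compound 4 (0.57 log units; beyond the scatter) is the widest yet at this saturated chain carbon bound to an oxygen on an aromatic ring, whereas a 1.4-fold higher number from compound 3 to compound 4 (0.14 log units; within the scatter) leaves 2-chlorophenyl and 4-methylphenyl unseparated. No measurement at hand offers a reason for these differences.

Still open, on these data alone, is how 4-chlorophenyl would compare, which would complete the set of chloro placements. Also open, as far as these compounds go, is whether a pyridyl ring, or a phenyl ring carrying an amine or a carboxylic acid, would move the number beyond the modest steps seen here.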